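Cyclopentyl on the Sulfonamide Nitrogen of a Urea Activator

The source may hold more compounds than are shown below. What is called first, only, known or untested is meant among the compounds shown, and "the series" means these compounds.

Measured compounds:
compound 1 `CNS(=O)(=O)c1ccc(NC(=O)NCc2ccncc2)cc1` with 3230 nM
compound 2 `CCOC(=O)c1ccc(NC(=O)NCc2cocn2)cc1` with 27600 nM
compound 3 `CCOC(=O)c1ccc(N/C(=N\C#N)NCc2ccncc2)cc1` with 41400 nM

Of the compounds shown here, three have been measured in an assay on isolated protein for activation of Nicotinamide phosphoribosyltransferase (Homo sapiens); a lower number here means that less compound is needed, a higher number that more compound is needed for the effect. Compound 1 gives 3230 nM and stands lowest of the three numbers; the gap to compound 2 and the gap to compound 3 both lie beyond the usual scatter, so compound 1 is the most potent of the measured set. Among the compounds with values here, compound 2 differs from compound 1 in more than one place, and so does compound 3, so no single-change step between measured compounds is available.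

The unmeasured compound 4 `CN(C1CCCC1)S(=O)(=O)c1ccc(NC(=O)NCc2ccncc2)cc1` is compound 1 with one change: cyclopentyl in place of hydrogen on a sulfonamide nitrogen. Nothing measured here shows directly what a group of this kind on the sulfonamide nitrogen does, so the expectation rests on compound 1 alone as the starting point. The author expects the step from compound 1 to compound 4 in this assay, a 2.2-fold lower number from compound 1 to compound 4 (0.33 log units; beyond the scatter), to be a modest lowering of the number, possibly within the scatter. Compound 4 is therefore estimated at 1500 nM, with a range from 400 nM to 6000 nM.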

Compound 4, half-maximal effective concentration: 123 nM
Beside the measured number, compound 4's estimate is 12-fold (1.09 log units) above it, and the stated range ends above it.
By their numbers in this assay, from the lowest: compound 4; then compound 1; then compounds 2 and 3 (each within the scatter of the next).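

In this assay, within the data shown here, cyclopentyl in place of hydrogen on the sulfonamide nitrogen gives a 26-fold lower number from compound 1 to compound 4 (1.42 log units; beyond the scatter), a large step and the first reading of what a single change does, since the earlier compounds differed from one another in more than one place. It shows that this nitrogen, which also carries a saturated chain carbon and the sulfonyl sulfur, accepts a five-membered carbon ring in place of its hydrogen, and that the number responds strongly to what sits there. Nothing available here accounts for the size of this step, and a single step cannot establish a trend at this position.

The compounds shown leave open whether the gain belongs to cyclopentyl itself or would also come with a cyclopropyl or cyclohexyl ring, an open isopropyl chain, or a tetrahydropyranyl ring with oxygen in it. They also leave open whether the methyl group on the same nitrogen is needed, a question that a cyclopentylamino sulfonamide carrying hydrogen in its place would answer.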